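Benzocyclobutene to indenyl with a shortened chain

The source may report more compounds than this note shows. Statements on the series, on what has been measured and on what is new or still open speak of the compounds shown alone.

Compound 1 `c1ccc2c(c1)CC2CCCN1CCN(c2cccc3c2OCCO3)CC1` sits second highest of the three numbers in an assay on isolated protein for binding affinity to 5-hydroxytryptamine receptor 1B (Rattus norvegicus) (on this read-out lower numbers stand for stronger inhibition and higher numbers for weaker inhibition), where compound 1 gives 646 nM. Compound 2 `c1ccc2c(c1)CCC2CCCN1CCN(c2cccc3c2OCCO3)CC1` gives 204 nM, and compound 3 `c1ccc2c(c1)CC(CCCN1CCN(c3cccc4c3OCCO4)CC1)C2` gives 1860 nM. The step of a 3.2-fold lower number from compound 1 to compound 2 (0.50 log units; beyond the scatter) and the step of a 2.9-fold higher number from compound 1 to compound 3 (0.46 log units; beyond the scatter) show that swapping the bicyclic group on the chain moves the number in either direction, and the step of a 9.1-fold higher number from compound 2 to compound 3 (0.96 log units; beyond the scatter) shows that the point of attachment within the same bicyclic group matters most.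

Compound 4 `C1=C(CCN2CCN(c3cccc4c3OCCO4)CC2)c2ccccc2C1` differs from compound 1 by a group of 9 heavy atoms (9 carbon; one five-membered non-aromatic ring of carbon only, one six-membered aromatic ring of carbon only) in place of a group of 9 heavy atoms (9 carbon; one four-membered non-aromatic ring of carbon only, one six-membered aromatic ring of carbon only), on a saturated chain carbon, two bonds along the chain from an amine nitrogen in a ring; the entering group carries one double bond outside aromatic rings, and the chain is one carbon shorter. For the measured compounds named here, no measured step combines a ring change with a chain change, so the bearing of the measured steps is indirect. The closest analogy is compound 2, whose group is attached at the carbon next to the aromatic ring, as in compound 4, and whose step from compound 1 was a modest lowering. Compound 4 is therefore expected to show a modest lowering of roughly a 2.2-fold lower number from compound 1 to compound 4 (0.33 log units; beyond the scatter) with wide uncertainty. Compound 4 is estimated at 300 nM, within 90 nM to 1000 nM.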

Compound 4, inhibition constant: 251 nM
Estimate against measurement, compound 4: 1.2-fold (0.08 log units) above, and the stated range covers the measured number.
By their numbers in this assay, from the lowest: compounds 2 and 4 (each within the scatter of the next); then compound 1; then compound 3.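

The five-membered ring group carrying a double bond outside aromatic rings, placed two bonds along the chain from the amine nitrogen in a ring, gives a 2.6-fold lower number from compound 1 to compound 4 (0.41 log units; beyond the scatter) in this assay. This step runs in the same direction as a 3.2-fold lower number from compound 1 to compound 2 (0.50 log units; beyond the scatter), so among the compounds shown, replacing the four-membered ring group can lower the number even when the attachment lies two bonds along the chain rather than three and the new group has a double bond outside aromatic rings. The step changes ring size, double bond and chain length together, so it cannot assign its size to any one of them, and no measurement given here explains the change.

As far as these compounds go, what remains open is how much each of these three changes contributes; 2,3-dihydro-1H-inden-1-yl attached two bonds along the chain from the amine nitrogen would separate the double bond from the chain length. The compounds shown also say nothing about a longer chain or a tetrahydronaphthyl group at this position.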